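The source may report more compounds than this note shows. Statements on the series, on what has been measured and on what is new or still open speak of the compounds shown alone.

Compounds measured so far in a functional assay (lung) for inhibition, with Cavia porcellus as the target; a higher number here means a weaker inhibitor, a lower number a stronger inhibitor:

Compound 1 `CCCC(CCc1nnn[nH]1)Cc1cccc(OCc2ccc3ccccc3n2)c1` gives 16 nM.
Compound 2 `c1ccc2nc(COc3ccc(OCCCc4nnn[nH]4)cc3)ccc2c1` gives 250 nM.
Compound 3 `CCCC(CCC(=O)O)Cc1cccc(OCc2ccc3ccccc3n2)c1` gives 70 nM.

Compound 3 stands second highest of the three numbers in this assay. Its nearest neighbour is compound 2, whose number is higher; its furthest is compound 1, whose number is lower. The one step that joins two of these compounds in a single place runs from compound 1 to compound 3: a 4.4-fold higher number from compound 1 to compound 3 (0.64 log units; beyond the scatter). Within the data shown here, compound 2 shares no single-place step with either of the others, so its value stands alone.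

Compound 4 `O=C(O)CCC(Cc1cccc(OCc2ccc3ccccc3n2)c1)c1ccccc1` differs from compound 3 in one place: phenyl in place of propyl on a saturated chain carbon bound to two saturated chain carbons. Among the measured compounds shown here, no measured step touches this kind of change; the only step on record concerns the acid end of the chain, not the group on the chain carbon, so it gives no direction for the new exchange. With nothing to lean on, the expectation for compound 4 is a number close to that of compound 3, with a wide range either way, and the step of no change at the digits printed from compound 3 to compound 4 (within the scatter) is expected to stay within the scatter. Compound 4 is thus estimated at 70 nM, between 20 nM and 250 nM.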

Compound 4, half-maximal inhibitory concentration: 56 nM
Compound 4: middle estimate off by 1.3-fold (0.10 log units), on the high side, within the range that was stated.
By their numbers in this assay, from the lowest: compound 1; then compounds 4 and 3 (each within the scatter of the next); then compound 2.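

In this assay, the saturated chain carbon bound to two saturated chain carbons carries phenyl in place of propyl with a 1.3-fold lower number from compound 3 to compound 4 (0.10 log units; within the scatter) and so stays within the scatter, even though a six-membered aromatic ring of carbon only enters where an open chain left. Among these compounds, this is the first reading at this position, since the one earlier step concerned the acid end of the chain, and within this single pair it shows that the two groups cannot be told apart by their numbers. The compounds shown offer no measurement that accounts for this result.

Still open is how the same chain carbon would read with a smaller or differently built group on it, such as a methyl, a hydroxy or an amine, since propyl and phenyl are the only two groups shown there. Also open, going by these compounds, is whether phenyl on this carbon would read the same with a 1H-tetrazol-5-yl at the end of the chain instead of the carboxy, the exchange that went beyond the scatter with propyl in place.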